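Capping the Amino Group of a Weak Hydrolase Inhibitor

The source may report more compounds than this note shows. Statements on the series, on what has been measured and on what is new or still open speak of the compounds shown alone.

Compound 1 `Nc1ccc(-c2cn(Cc3cc(C(=O)O)cc(-c4ccccc4C(=O)O)c3)nn2)cc1` has the lowest number of the three measured compounds in an assay on cells for inhibition of ubiquitin carboxyl-terminal hydrolase isozyme L5 (Homo sapiens), read by fluorescence, with a stated time of 30 min (on this read-out lower numbers stand for stronger inhibition and higher numbers for weaker inhibition), where it gives 80500 nM. Compound 2 `Nc1ccc(-c2cn(Cc3cccc(-c4ccccc4C(=O)O)c3)nn2)cc1` gives 116000 nM, a step of a 1.4-fold higher number from compound 1 to compound 2 (0.16 log units; within the scatter); compound 3 `Nc1ccc(-c2cn(Cc3cc(C(=O)O)cc(-c4ccc(C(=O)O)cc4)c3)nn2)cc1` gives 285000 nM, a step of a 3.5-fold higher number from compound 1 to compound 3 (0.55 log units; beyond the scatter). Compound 4 `CC(=O)Nc1ccc(-c2cn(Cc3cc(C(=O)O)cc(-c4ccccc4C(=O)O)c3)nn2)cc1` differs from compound 1 by acetyl in place of hydrogen on a nitrogen on an aromatic ring. Neither measured step touches this part of the molecule: both concern carboxy groups, not the nitrogen on the aromatic ring. For the measured compounds named here, no measured step therefore bears on the change, and with every number here already weak, the expected step is a 1.5-fold higher number from compound 1 to compound 4 (0.17 log units; within the scatter), which amounts to no change beyond the scatter. Compound 4 is thus estimated at 120000 nM, with a range from 40000 nM to 400000 nM.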

Compound 4, half-maximal inhibitory concentration: 80900 nM
For compound 4 the middle estimate is 1.5-fold (0.17 log units) above the measured one; the range from low to high includes it.
By their numbers in this assay, from the lowest: compounds 1, 4 and 2 (each within the scatter of the next); then compound 3.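

In this assay the change from amino to acetamido gives a 1.0-fold higher number from compound 1 to compound 4 (0.00 log units; within the scatter) and so leaves the two compounds indistinguishable. For the compounds shown here, this is the first reading at this nitrogen, and it shows that the weak inhibition of compound 1 does not depend on a free amino group and that an acetyl can sit here. Nothing measured here explains this result. Going by these compounds, whether a methanesulfonyl group or a longer acyl chain on this nitrogen would also match compound 1 remains open.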